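This account rests on a few compounds, and the source may have more. Where it says the series, first, only, none or still open, it means among the compounds named here.

Of the compounds shown here, three have been measured in an ADME assay on the whole organism with Oryza sativa as the target, tested at 1 uM; on this read-out higher numbers stand for a weaker effect at the one concentration tested and lower numbers for a stronger effect. Compound 1, with the structure `CCCc1ccc(NC(=O)N[C@@H](C)c2ccccc2)cc1`, gives 76%. Compound 2, with the structure `CCCCCc1ccc(NC(=O)N[C@@H](C)c2ccccc2)cc1`, gives 98%. Within the data shown here, the one measured step between these two, a number 22 percentage points higher from compound 1 to compound 2 (beyond the scatter), concerns a chain on one ring and nothing else. Compound 3, with the structure `C[C@@H](NC(=O)Nc1ccc(F)cc1)c1ccccc1`, gives 96% in this assay. Its number sits within the scatter of the number of compound 2, so the two cannot be told apart, while it lies beyond the scatter above the number of compound 1.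

Compound 4, with the structure `C[C@H](NC(=O)Nc1ccc(F)cc1)c1ccccc1`, has not yet been measured. It differs from compound 3 as follows: the two compounds have the same atoms and bonds and differ only in configuration as drawn: 1 of 1 stereo elements differ; a stereocentre at a saturated chain carbon is drawn R in compound 3 and S in compound 4. Among the measured compounds shown here, none of the measured steps bears on this change, since the only step seen, a number 22 percentage points higher from compound 1 to compound 2 (beyond the scatter), alters a chain rather than a configuration, and no pair among the measured compounds differs in configuration alone. There is therefore no measured basis for a step in either direction, and the estimate is wide. The step expected is a number 11 percentage points lower from compound 3 to compound 4 (beyond the scatter), with the number of compound 4 estimated at 85%, within a range from 55% to 100%.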

Compound 4, a percentage reported as activity, at one concentration (the size of the read-out at that concentration, not a potency): 97%
Beside the measured number, compound 4's estimate is 12 percentage points below it; low and high end bracket the measured number.
By their numbers in this assay, from the lowest: compound 1; then compounds 3, 4 and 2 (each within the scatter of the next).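

Changing the drawn configuration at the saturated chain carbon from R to S gives a number 1 percentage points higher from compound 3 to compound 4 (within the scatter) in this assay, so with fluoro on the aromatic carbon the two drawn forms cannot be told apart on this read-out, and the comparison is a clean one: the fact that compounds 3 and 4 differ only in the configuration as drawn

Fluoro in place of pentyl on an aromatic carbon gives a number 1 percentage points lower from compound 2 to compound 4 (within the scatter), so this compound in the S form also cannot be told apart from the pentyl compound, just as compound 3 could not. Fluoro in place of propyl on an aromatic carbon gives a number 21 percentage points higher from compound 1 to compound 4 (beyond the scatter), which shows that the gap seen earlier between compound 1 and compound 3 holds for the other drawn configuration as well.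

Among these compounds, the only pair that differs in configuration alone carries fluoro and sits at the weak end of the read-out, so whether configuration matters in the propyl series, where compound 1 shows a stronger effect, remains open. As far as these compounds go, how a butyl chain or a methoxy group on that aromatic carbon would read also remains open, and with it what happens between propyl and pentyl.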